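A few compounds are considered here, and "the series" means these few. Any claim that something is new, unique, unknown or untested is made for them only; others in the source may bear on it.

Measured so far in an ADME assay on MT2 cells (Homo sapiens) for cytotoxicity, read by MTT assay; a lower number here means that less compound is tolerated, a higher number that more compound is tolerated:
compound 1 `COCc1ccc(Nc2nnc(Cc3c(Cl)cccc3Cl)o2)cc1` gives 100000 nM
compound 2 `Fc1cccc(F)c1Cc1cnc(Nc2ccc(Oc3ccncc3)c(Cl)c2)o1` gives 21000 nM
compound 3 `Fc1cccc(F)c1Cc1cnc(Nc2ccc(Oc3ccncc3)cc2)o1` gives 21000 nM

Compound 3 stands level with compound 2 at the digits shown; together these two are the lowest numbers of the three. Compound 1 lies furthest from compound 3, its number higher by an amount beyond the scatter. Going by the values given here, the single measured step, no change at the digits printed from compound 2 to compound 3 (within the scatter), left this assay unchanged and concerns a group other than the one altered next.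

Compound 4 `Fc1cccc(F)c1Cc1cnc(Nc2ccc(COc3ccncc3)cc2)o1` differs from compound 3 at one place: ((pyridin-4-yl)oxy)methyl in place of (pyridin-4-yl)oxy on an aromatic carbon. Among the compounds with values here, no measured step bears on this change; the one step available did not move the number, and nothing points to a shift in either direction. Compound 4 is therefore expected to sit close to compound 3, with an estimated step of no change at the digits printed from compound 3 to compound 4 (within the scatter), within the scatter. For compound 4 the estimate in this assay is 21000 nM, with a range from 8000 nM to 60000 nM.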

Compound 4, half-maximal cytotoxic concentration: > 100000 nM
Compound 4: only a limit was reported (the forecaster's own chance of this, stated with the estimate: 15%); middle value at least 4.7-fold (0.67 log units) from the limit.
By their numbers in this assay, from the lowest: compounds 2 and 3 (each within the scatter of the next); then compound 1.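

In this assay compound 4 gives > 100000 nM, which is a limit of the assay and not a number. With ((pyridin-4-yl)oxy)methyl in place of (pyridin-4-yl)oxy, on the aromatic carbon para to a large group, the series shows an at least 4.7-fold higher number from compound 3 to compound 4 (0.67 log units; beyond the scatter), so this position moves the number in this assay, whereas the earlier change of hydrogen in place of chloro showed no change at the digits printed from compound 2 to compound 3 (within the scatter). The printed step is a lower bound, and its full size cannot be read: the limit of > 100000 nM in this assay, at which 1 of the 4 values shown sits.

Going by these compounds, whether an amine in place of the oxygen of ((pyridin-4-yl)oxy)methyl, or a longer chain carrying the pyridin-4-yl group, would keep the number at this limit remains open. Also open, on these data alone, is whether chloro on the ring of compound 4 would change its reading, given that the step to hydrogen on compound 2 left the number unchanged.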